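Trading Dichlorophenyl for Methoxyphenyl on the Shared Core

A few compounds are considered here, and "the series" means these few. Any claim that something is new, unique, unknown or untested is made for them only; others in the source may bear on it.

Compound 1 `Nc1cc(N)c2nc(-c3ccccc3)c(NCc3ccc(Cl)c(Cl)c3)nc2c1` was tested in a functional assay on HCT-116 cells (Homo sapiens) for inhibition, read by sulforhodamine B assay, with a stated time of 48 h (a higher number here means that more compound is tolerated, a lower number that less compound is tolerated), where compound 1 gave 50100 nM. Compound 2 `CCOC(=O)[C@H](CCC(=O)O)NC(=O)c1ccc(Oc2nc3cc(N)cc(N)c3nc2-c2ccccc2)cc1` shares the same core, and in this assay compound 2 gave 53700 nM; the two numbers lie within the scatter of each other, so neither compound can be placed above the other on this read-out. Compound 3 `COc1ccc(CNc2nc3cc(N)cc(N)c3nc2-c2ccccc2)cc1` differs from compound 1 by a single exchange: 4-methoxyphenyl in place of 3,4-dichlorophenyl on a saturated chain carbon bound to a nitrogen on an aromatic ring. Among the compounds with values here, no measured pair shows this exchange, so the only guide is that both measured compounds sit near the same concentration. The step from compound 1 to compound 3 is expected to be small, close to the scatter and without a clear direction, as a 1.2-fold higher number from compound 1 to compound 3 (0.08 log units; within the scatter). Compound 3 is therefore estimated at 60000 nM in this assay, within a range from 25000 nM to 150000 nM.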

Compound 3, concentration lethal to 50% of the cells: 52500 nM
The estimate for compound 3 lay 1.1-fold (0.06 log units) above the measured number; the range from low to high includes it.
By their numbers in this assay, from the lowest: compounds 1, 3 and 2 (each within the scatter of the next).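

In this assay, within the data shown here, the exchange of 3,4-dichlorophenyl for 4-methoxyphenyl on a saturated chain carbon bound to a nitrogen on an aromatic ring gives a 1.0-fold higher number from compound 1 to compound 3 (0.02 log units; within the scatter), the first step that can be read at this position. For this one pair, then, losing both chlorine atoms and gaining an oxygen and a hydrogen-bond acceptor leaves the read-out within the scatter. Nothing available explains this outcome.

From the compounds shown here alone, it remains open whether the read-out would stay as level with an amine or a carboxylic acid in place of the methoxy group, or with a longer chain in place of the benzyl group. Among these compounds, the single pair also leaves open whether other groups at this position would separate beyond the scatter.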